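Swapping methoxy for nitro on the chalcone ketone aryl

This account rests on a few compounds, and the source may have more. Where it says the series, first, only, none or still open, it means among the compounds named here.

Measured compounds:
- compound 1, `COc1ccc(C(=O)/C=C/c2ccc(OCc3cn(Cc4cccc(Br)c4)nn3)cc2)cc1`: 47%
- compound 2, `COc1ccc(C(=O)/C=C/c2ccc(OCc3cn(Cc4ccc(Br)cc4)nn3)cc2)cc1`: 50%
- compound 3, `COc1ccc(C(=O)/C=C/c2ccc(OCc3cn(Cc4ccccc4F)nn3)cc2)cc1`: 21%

All three were tested in a functional assay on A549 cells (Homo sapiens) for inhibition, read by MTT assay, with a stated time of 48 h, tested at 10 uM; on this read-out higher numbers stand for more inhibition of growth at the one concentration tested and lower numbers for less inhibition of growth. Compound 2 gives the highest of the three numbers, but compound 1 sits close to it: the step of a number 3 percentage points higher from compound 1 to compound 2 (within the scatter) is within the scatter, so the two cannot be told apart. Compound 3 is clearly separated, as the step of a number 29 percentage points lower from compound 2 to compound 3 (beyond the scatter) shows, and the step of a number 26 percentage points lower from compound 1 to compound 3 (beyond the scatter) points the same way.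

The unmeasured compound 4, `O=C(/C=C/c1ccc(OCc2cn(Cc3ccc(Br)cc3)nn2)cc1)c1ccc([N+](=O)[O-])cc1`, differs from compound 2 at the other end of the shared core: nitro in place of methoxy on an aromatic carbon. Every measured step changes only the substituted benzyl group on the triazole nitrogen; none touches the aryl ketone end. Going by the values given here, there is therefore no measured step that bears on this change, and no direction can be read from the data. The expectation for compound 4 in this assay is simply a value near that of compound 2, with a wide range to reflect the absence of guidance: compound 4 is estimated at 46%, between 22% and 70%. The step this implies, a number 4 percentage points lower from compound 2 to compound 4 (within the scatter), is expected to lie within the scatter.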

Compound 4, percent growth inhibition at one concentration: 18%
Compound 4: the middle estimate sits 28 percentage points above what was measured, and the stated range ends above it.
By their numbers in this assay, from the lowest: compounds 4 and 3 (each within the scatter of the next); then compounds 1 and 2 (each within the scatter of the next).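

The aryl group on the ketone side is not a silent part of the molecule in this assay: replacing methoxy with nitro gives a large change (a number 32 percentage points lower from compound 2 to compound 4 (beyond the scatter)). Going by these compounds alone, every earlier step changed only the substituted benzyl group, so the earlier compounds showed nothing about this site; this single swap on an aromatic carbon, para to a large group, now moves the number beyond the scatter. Nothing shown here explains why the nitro compound gives less growth inhibition than its methoxy partner.

Within the data shown here, with only two groups at this site, it remains open whether nitro lowers the number, methoxy raises it, or both, and an unsubstituted phenyl ring, a chlorine atom or a dimethylamino group at the same place would help separate these possibilities. From the compounds shown here alone, it also remains open whether the same swap would have a similar effect alongside the 3-bromophenyl or 2-fluorophenyl groups, and whether the single concentration and the one cell line used here reflect how these compounds behave more widely.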